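The compounds below may be only part of what the source reports. "The series", "measured", "known", "first", "only" and "open" are said of these compounds alone.

Compound 3 `Cn1nnnc1SCC(=O)N/N=c1/scc(-c2ccc(Br)cc2)n1-c1ccccc1` is recorded as "not determined" (no result reported) in a functional assay on C6 cells (Rattus norvegicus) for cytotoxicity, read by MTT assay, with a stated time of 24 h (on this read-out lower numbers stand for stronger inhibition and higher numbers for weaker inhibition), so it has no standing on the numbers shown. Compound 1 `Cc1ccc(-c2cs/c(=N/NC(=O)CSc3nnnn3-c3ccccc3)n2-c2ccccc2)cc1` gives 14.7 ug/mL in this assay, and compound 2 `Cc1ccc(-c2cs/c(=N/NC(=O)CSc3nncn3C)n2-c2ccccc2)cc1` gives 56 ug/mL. For the measured compounds named here, the only measured step, a 3.8-fold higher number from compound 1 to compound 2 (0.58 log units; beyond the scatter), concerns the group on the sulfur. Compound 4 `Cc1ccc(-c2cs/c(=N/NC(=O)CSc3nnnn3C)n2-c2ccccc2)cc1` differs from compound 3 by methyl in place of bromo on an aromatic carbon. Going by the values given here, no measured step involves methyl in place of bromo on an aromatic carbon, so the size of that change cannot be read from the series; the step from compound 1 to compound 2 does not bear on it. Compound 4 shares its 4-methylphenyl with compounds 1 and 2, whose values bracket the working expectation. Compound 4 is expected to give 30 ug/mL in this assay, with a range from 10 ug/mL to 90 ug/mL.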

Compound 4, half-maximal inhibitory concentration: 36.3 ug/mL
Compound 4: middle estimate off by 1.2-fold (0.08 log units), on the low side; the range from low to high includes it.
By their numbers in this assay, from the lowest: compound 1; then compounds 4 and 2 (each within the scatter of the next).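

With the tetrazole kept on the sulfur, methyl in place of phenyl on an aromatic nitrogen gives a 2.5-fold higher number from compound 1 to compound 4 (0.39 log units; beyond the scatter) in this assay. Changing only the ring on the sulfur, 1-methyl-1H-tetrazol-5-yl in place of 4-methyl-4H-1,2,4-triazol-3-yl, gives a 1.5-fold lower number from compound 2 to compound 4 (0.19 log units; within the scatter), so the new compound separates the two changes combined in the earlier step. Among these compounds, the phenyl on the nitrogen, not the ring type, marks the clear difference.

From the compounds shown here alone, the step from 4-bromophenyl to 4-methylphenyl cannot be read, and what an amine or a carboxylic acid would do in place of that methyl or bromo stays open. No measurement on hand accounts for any of these steps.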